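Swapping One Ring on a Rapidly Cleared Compound

The source may report more compounds than this note shows. Statements on the series, on what has been measured and on what is new or still open speak of the compounds shown alone.

Compound 1 `O=c1[nH]ccn1CCOc1nn(-c2ccccc2F)c2ccc(F)cc12` - 783 mL/min/kg
Compound 2 `CC(Oc1nn(-c2ccccc2F)c2ccc(F)cc12)C(=O)N1CCOCC1` - 717 mL/min/kg

Both compounds were tested in an ADME assay on liver for metabolic stability, with Liver microsome (Rattus norvegicus) as the target, using microsomes and NADPH, with a stated time of 30 min, tested at 0.5 uM; a lower number here means slower removal, a higher number faster removal of the compound. Going by the values given here, there, compound 1 gives 783 mL/min/kg, the top number of the two measured so far. That position means little, since compound 2, at 717 mL/min/kg, lies within the usual scatter of compound 1, and the two cannot be told apart.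

Compound 3 `CN1CCN(CCOc2nn(-c3ccccc3F)c3ccc(F)cc23)C1=O` keeps the core of compound 1 and changes one group. The change is a group of 7 heavy atoms (4 carbon, 2 nitrogen, 1 oxygen; one five-membered non-aromatic ring with 2 hetero atoms) in place of a group of 6 heavy atoms (3 carbon, 2 nitrogen, 1 oxygen; one five-membered aromatic ring with 2 hetero atoms), on a saturated chain carbon, two bonds along the chain from an oxygen on an aromatic ring. The new group, 3-methyl-2-oxoimidazolidin-1-yl, sits on a saturated chain carbon, two bonds along the chain from an oxygen on an aromatic ring.

Among the compounds with values here, no measured pair differs in just one place, so the data show no direct precedent for this swap. Within the data shown here, the only guide is that compound 2, with its different side chain, stays at 717 mL/min/kg in this assay. On that slender basis, no step beyond the scatter is expected, and no direction is favoured. The expected change is a 1.1-fold lower number from compound 1 to compound 3 (0.05 log units; within the scatter). For compound 3 the estimate is 700 mL/min/kg, with an expected range from 400 mL/min/kg to 1100 mL/min/kg.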

Compound 3, clearance: 7200 mL/min/kg
Beside the measured number, compound 3's estimate is 10-fold (1.01 log units) below it; measured number above the stated range.
By their numbers in this assay, from the lowest: compounds 2 and 1 (each within the scatter of the next); then compound 3.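

In this assay, going by these compounds alone, this place on the chain proves far from indifferent: putting 3-methyl-2-oxoimidazolidin-1-yl in place of the five-membered aromatic ring gives a 9.2-fold higher number from compound 1 to compound 3 (0.96 log units; beyond the scatter) and so moves the number well beyond the usual scatter, the first step that can be read. The swap alters several things at once, since the new ring is non-aromatic, has 7 heavy atoms instead of 6, and has 0 hydrogen-bond donors instead of 1, so this single step cannot show which of these differences matters. No measurement in hand explains why compound 3 is cleared so much faster than compound 1.

Still open, on these data alone, is whether the plain 2-oxoimidazolidin-1-yl ring, lacking the methyl group but keeping the ring hydrogen on nitrogen, would stay close to compound 1 or land close to compound 3. Also open, as far as these compounds go, is how a quite different group in the same place, such as a dimethylamino group or a carboxylic acid, would behave in this assay.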